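The source may hold more compounds than are shown below. What is called first, only, known or untested is meant among the compounds shown, and "the series" means these compounds.

Measured so far:
- compound 1 `Cc1ccncc1C(=O)N1CC(Oc2cncc(N3C(=O)c4ccc(Cl)cc4C3(C)C)c2)C1`: 40%
- compound 2 `CCS(=O)(=O)N1CCC(c2cncc(N3C(=O)c4ccc(Cl)cc4C3(C)C)c2)CC1`: 87%

In an ADME assay on the whole organism (Rattus norvegicus, strain Wister-Han) for pharmacokinetics, read by LC-MS, at a dose of 3 mg/kg by the oral route (on this read-out higher numbers stand for higher oral bioavailability and lower numbers for lower oral bioavailability), compound 1 gives 40%, the lower of the two numbers. Compound 2 gives 87%, a gap beyond the usual scatter. Within the data shown here, no pair of measured compounds differing in one place is available, so the series offers no measured step to scale from.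

The next compound is compound 3 `CC1(C)c2cc(Cl)ccc2C(=O)N1c1cncc(OC2CN(C(=O)c3ncccc3Cl)C2)c1`. It differs from compound 1 as follows: 3-chloropyridin-2-yl in place of 4-methylpyridin-3-yl on a carbonyl carbon. In words, 3-chloropyridin-2-yl stands in place of 4-methylpyridin-3-yl on a carbonyl carbon, with the rest of the structure unchanged.

As far as these compounds go, with nothing measured for this exchange, no step beyond the scatter is expected in this assay, and the direction stays open. The expected change is a number 5 percentage points higher from compound 1 to compound 3 (within the scatter). The estimate starts from compound 1 at 40%, with a wide range. The estimated value for compound 3 is 45%, with an expected range of 20% to 70%.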

Compound 3, oral bioavailability: 58%
Beside the measured number, compound 3's estimate is 13 percentage points below it, and the stated range covers the measured number.
By their numbers in this assay, from the lowest: compound 1; then compound 3; then compound 2.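

In this assay, the group on the carbonyl carbon whose other neighbour is the amide-type nitrogen in a ring now has its first measured step: 3-chloropyridin-2-yl in place of 4-methylpyridin-3-yl gives a number 18 percentage points higher from compound 1 to compound 3 (beyond the scatter). This position therefore responds to the exchange, even though the two groups match in heavy-atom count, hydrogen-bond donors, hydrogen-bond acceptors and net charge. No measurement shown bears on what lies behind the step.

The exchange alters the ring substituent, from methyl to chlorine, together with the point of attachment of the pyridine, so the share of each in the step stays unresolved. As far as these compounds go, whether 3-methylpyridin-2-yl or an unsubstituted pyridin-2-yl at this position would give a similar number also remains open.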